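Thiosemicarbazone series: hydroxy in place of ring methyl

The compounds below may be only part of what the source reports. "The series", "measured", "known", "first", "only" and "open" are said of these compounds alone.

Compound 3 `Cc1cccc(/C=N/NC(N)=S)c1` is the reference for the next step. For the measured compounds named here, in a functional assay on B16 cells (Mus musculus) for inhibition (on this read-out lower numbers stand for stronger inhibition and higher numbers for weaker inhibition), compound 3 gives 2800 nM, the lowest of the three numbers so far. Compound 2 `CCc1ccc(/C=N/NC(N)=S)cc1` stands nearest to it: in this assay compound 2 gives 3400 nM, within the scatter of compound 3, so no order between the two is claimed. Compound 1 `Cc1ccc(/C=N/NC(N)=S)cc1` stands furthest away: in this assay compound 1 gives 6800 nM, beyond the scatter of compound 3.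

Compound 4 `NC(=S)N/N=C/c1cccc(O)c1` differs from compound 3 as follows: hydroxy in place of methyl on an aromatic carbon. Going by the values given here, the one step measured so far, a 2.0-fold lower number from compound 1 to compound 2 (0.30 log units; within the scatter), concerns a methyl added on a saturated chain carbon, not a substituent exchanged on the ring, and it lies within the scatter. Among the compounds with values here, no measured step shows what a hydroxy group does on the ring; the data give no basis for a direction. The step from compound 3 to compound 4 in this assay is therefore estimated as a 1.1-fold higher number from compound 3 to compound 4 (0.03 log units; within the scatter), with no movement beyond the scatter expected. For compound 4 in this assay the expected value is 3000 nM, estimated to lie between 1000 nM and 9000 nM.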

Compound 4, half-maximal inhibitory concentration: 24000 nM
For compound 4 the middle estimate is 8.0-fold (0.90 log units) below the measured one; measured number above the stated range.
By their numbers in this assay, from the lowest: compounds 3, 2 and 1 (each within the scatter of the next, the first and the last beyond it); then compound 4.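

In this assay, the place on the aromatic ring that carries methyl in compound 3 proves sensitive to what sits there: hydroxy in place of methyl gives an 8.6-fold higher number from compound 3 to compound 4 (0.93 log units; beyond the scatter), toward weaker inhibition, and of the two steps in hand this is the only one beyond the scatter. The exchange leaves the heavy-atom count unchanged and adds one hydrogen-bond donor and one hydrogen-bond acceptor, so swapping a single heavy atom on this aromatic carbon is enough to produce a step of this size. Nothing at hand bears on what lies behind the step.

The compounds shown leave open whether the step reflects the arrival of hydroxy or the departure of methyl, and a bare hydrogen, a methoxy group or an amine on the same aromatic carbon would help separate the two. Also open, as far as these compounds go, is whether hydroxy would give a step in the same direction on the ring carbon that carries methyl in compound 1.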